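The compounds below may be only part of what the source reports. "The series", "measured", "known", "first", "only" and "open" are said of these compounds alone.

Measured in a functional assay on DU-145 cells (Homo sapiens) for cytotoxicity, read by MTT assay; on this read-out higher numbers stand for weaker inhibition and lower numbers for stronger inhibition:
- compound 1 `CC(C)=CC[C@@H](OC[C@@H](C)O)C1=CC(=O)c2c(O)ccc(O)c2C1=O`: 14300 nM
- compound 2 `CCCCC(O)CC(=O)O[C@H](CC=C(C)C)C1=CC(=O)c2c(O)ccc(O)c2C1=O`: 45300 nM
- compound 3 `CCCCC(CC(=O)O[C@H](CC=C(C)C)C1=CC(=O)c2c(O)ccc(O)c2C1=O)OC(C)=O`: 67700 nM

Compound 3 lies within the scatter of compound 2 and clearly apart from compound 1. Compound 4 `CC(C)=CC[C@@H](OC(=O)C1CCOC1)C1=CC(=O)c2c(O)ccc(O)c2C1=O` is reached by oxolan-3-yl in place of 2-acetoxyhexyl on a carbonyl carbon, with oxolan-3-yl in place of 2-acetoxyhexyl on a carbonyl carbon. Going by the values given here, no measured step makes this exchange. Among the compounds with values here, the closest evidence is a 1.5-fold higher number from compound 2 to compound 3 (0.17 log units; within the scatter), a change within the 2-acetoxyhexyl group, and a 3.2-fold higher number from compound 1 to compound 2 (0.50 log units; beyond the scatter), which is the only step beyond the scatter. Both are small, so only a modest step toward the lower numbers is expected. The expected step is a 2.3-fold lower number from compound 3 to compound 4 (0.35 log units; beyond the scatter). For compound 4 the estimate is 30000 nM, with an estimated range of 13000 nM to 65000 nM.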

Compound 4, half-maximal inhibitory concentration: 47500 nM
Compound 4: middle estimate off by 1.6-fold (0.20 log units), on the low side; low and high end bracket the measured number.
By their numbers in this assay, from the lowest: compound 1; then compounds 2, 4 and 3 (each within the scatter of the next).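

In this assay, oxolan-3-yl on the carbonyl carbon gives a 1.4-fold lower number from compound 3 to compound 4 (0.15 log units; within the scatter) and a 1.0-fold higher number from compound 2 to compound 4 (0.02 log units; within the scatter), so at this position the ring matches the open 2-acetoxyhexyl and 2-hydroxyhexyl chains within the scatter. Compound 1, with its 2-hydroxypropyl, stays apart, with a 3.3-fold higher number from compound 1 to compound 4 (0.52 log units; beyond the scatter), which repeats the separation first seen with compound 2. No available measurement accounts for these results. As far as these compounds go, whether an amine or a carboxylic acid on the carbonyl carbon would shift the number remains open, as does the effect of changes to the shared core.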